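A Thiazole for a Pyrazole on the Pyridine Amine

A few compounds are considered here, and "the series" means these few. Any claim that something is new, unique, unknown or untested is made for them only; others in the source may bear on it.

Compound 1, `CC(Oc1cccnc1Nc1cnn(C)c1)c1cccc(C(=O)NCc2ccc(F)cc2)c1`: 43800 nM
Compound 2, `Cc1ccc(CNC(=O)c2cccc(C(C)Oc3cccnc3Nc3cnn(CC(C)(C)O)c3)c2)cc1`: 9100 nM

Among the compounds with values here, in a functional assay on NCI-H3122 cells (Homo sapiens) for antiproliferative activity, read by MTT assay, with a stated time of 48 h (a higher number here means a weaker inhibitor, a lower number a stronger inhibitor), compound 2 gives the lower of the two numbers measured so far, and the value of compound 1 lies beyond the usual scatter above it. Compound 3, `Cc1ccc(CNC(=O)c2cccc(C(C)Oc3cccnc3Nc3ncc(C)s3)c2)cc1`, differs from compound 2 by 5-methyl-1,3-thiazol-2-yl in place of 1-(2-hydroxy-2-methylpropyl)-1H-pyrazol-4-yl on a nitrogen on an aromatic ring. Within the data shown here, no measured pair shows this change, so the size of its effect is unknown; a step not beyond the scatter, in either direction, is expected. Compound 3 is estimated at 12000 nM, with a range from 3000 nM to 50000 nM. This means an expected step of a 1.3-fold higher number from compound 2 to compound 3 (0.12 log units; within the scatter).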

Compound 3, half-maximal inhibitory concentration: 8500 nM
The estimate for compound 3 lay 1.4-fold (0.15 log units) above the measured number; the range from low to high includes it.
By their numbers in this assay, from the lowest: compounds 3 and 2 (each within the scatter of the next); then compound 1.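

In this assay, 5-methyl-1,3-thiazol-2-yl in place of 1-(2-hydroxy-2-methylpropyl)-1H-pyrazol-4-yl on the nitrogen gives a 1.1-fold lower number from compound 2 to compound 3 (0.03 log units; within the scatter), so the step stays within the scatter. At this place, the ring can thus be exchanged and the hydroxy-bearing chain lost, with fewer heavy atoms and no hydrogen-bond donor in the group, without a step beyond the scatter. Nothing measured here accounts for this result. The compounds shown leave open whether an amine or a carboxylic acid on this ring, or a pyridine in its place, would give a step beyond the scatter.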